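This account rests on a few compounds, and the source may have more. Where it says the series, first, only, none or still open, it means among the compounds named here.

Compound 1, `COc1ccc(C(=O)/C=C/c2cn(-c3ccccc3)nc2-c2ccsc2)c(OC)c1OC`, is the starting point. In a functional assay on Huh-7 cells (Homo sapiens) for inhibition, read by sulforhodamine B assay, with a stated time of 72 h (on this read-out lower numbers stand for stronger inhibition and higher numbers for weaker inhibition), compound 1 gives 4200 nM, the highest of the three numbers seen so far. Compound 2, `COc1ccc(C(=O)/C=C/c2cn(-c3ccccc3)nc2-c2ccsc2)cc1OC`, gives 2900 nM, and compound 3, `COc1ccc(C(=O)/C=C/c2cn(-c3ccccc3)nc2-c2ccsc2)c(OC)c1`, gives 3000 nM. Removing one methoxy group changed little: a 1.4-fold lower number from compound 1 to compound 2 (0.16 log units; within the scatter) and a 1.4-fold lower number from compound 1 to compound 3 (0.15 log units; within the scatter), while between the two compounds with fewer methoxy groups a 1.0-fold higher number from compound 2 to compound 3 (0.01 log units; within the scatter). Compound 4, `COc1ccc(C(=O)/C=C/c2cn(-c3ccccc3)nc2-c2cccnc2)c(OC)c1OC`, keeps the methoxy groups of compound 1 and differs in another part of the molecule: pyridin-3-yl in place of thiophen-3-yl on an aromatic carbon. For the measured compounds named here, none of the measured steps touches this part; all three concern the methoxy pattern on the ring that sits on the carbonyl carbon, and each stayed within the scatter. There is thus no measured basis for expecting a step beyond the scatter in this assay in either direction, and the uncertainty is wide. The estimate for compound 4 is 4200 nM, within a range from 1400 nM to 12600 nM, which corresponds to an expected step of no change at the digits printed from compound 1 to compound 4 (within the scatter).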

Compound 4, half-maximal inhibitory concentration: 2300 nM
Compound 4: the middle estimate sits 1.8-fold (0.26 log units) above what was measured; measured number inside the range.
By their numbers in this assay, from the lowest: compounds 4, 2, 3 and 1 (each within the scatter of the next).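

For the compounds shown here, compounds 1 to 3 varied only the methoxy groups, whereas compound 4 is the first to alter the group on the aromatic carbon of the five-membered aromatic ring with 2 nitrogen. In this assay, putting pyridin-3-yl in place of thiophen-3-yl gives a 1.8-fold lower number from compound 1 to compound 4 (0.26 log units; within the scatter) and so, although one ring is five-membered with sulfur and the other six-membered with nitrogen, this single exchange does not move the number beyond the scatter. No supporting measurement says how either ring acts in these cells.

From the compounds shown here alone, it remains open whether a non-ring group at this position, such as an amine or a longer alkyl chain, would shift the number beyond the scatter. Also open, going by these compounds, is whether pyridin-3-yl would behave the same way alongside the methoxy patterns of compound 2 and compound 3.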